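The source may report more compounds than this note shows. Statements on the series, on what has been measured and on what is new or still open speak of the compounds shown alone.

The series is assessed in a toxicity assay on NIH3T3 cells (Mus musculus) for cytotoxicity, read by resazurin assay; a lower number here means that less compound is needed, a higher number that more compound is needed for the effect. Compound 1 `COC(=O)c1ccc(NCc2cncn2Cc2ccccc2-c2ccccc2)cc1-c1ccccc1` has "not determined" (no result reported) there. In this assay compound 2 `COC(=O)c1ccc(NCc2cncn2Cc2cccc(N)c2)cc1-c1ccccc1` gives only a limit of > 10000 nM, not a number. Compound 2 therefore sits at the limit of > 10000 nM in this assay, at which 1 of the 2 values shown sits, while the other entry carries no single number at all. Compound 3 `COC(=O)c1ccc(NCc2cncn2Cc2ccccc2[N+](=O)[O-])cc1-c1ccccc1` differs from compound 2 by 2-nitrophenyl in place of 3-aminophenyl on a saturated chain carbon bound to an aromatic nitrogen. Among the compounds with values here, no measured step gives a guide here, so in this assay the change from compound 2 to compound 3 is expected to stay within the scatter, a step that the limit leaves unreadable from compound 2 to compound 3. Compound 3 is estimated at 15000 nM, in a range from 5000 nM to 50000 nM, most probably reported again as a limit.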

Compound 3, half-maximal effective concentration: 10000 nM
Compound 3: the middle estimate sits 1.5-fold (0.18 log units) above what was measured, within the range that was stated.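

In this assay the change from 3-aminophenyl to 2-nitrophenyl, on a saturated chain carbon bound to an aromatic nitrogen, gives a number no higher from compound 2 to compound 3 (the limit leaves the size open). Within the data shown here, compound 3 supplies the first single number at this position, 10000 nM. Compound 2 remains a limit, so the size of this step cannot be read: the limit of > 10000 nM in this assay, at which 1 of the 3 values shown sits.

The compounds shown leave open how large this change actually is. Also open, on these data alone, is how a 3-nitrophenyl at this place would read in this assay, which would separate the exchange of amino for nitro from the shift in ring position.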